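A Single Stereocentre Changed on a Weak Inhibitor

The source may report more compounds than this note shows. Statements on the series, on what has been measured and on what is new or still open speak of the compounds shown alone.

In a functional assay on Vero cells (Chlorocebus sabaeus) for inhibition (on this read-out higher numbers stand for weaker inhibition and lower numbers for stronger inhibition), compound 1 `Nc1nc(Cl)c2ncn([C@H]3CS[C@@H](CO)O3)c2n1` is recorded at > 100000 nM as a limit of the assay. For the measured compounds named here, compound 2 `OC[C@H]1O[C@H](n2cnc3c(Cl)ncnc32)CS1` gives 86100 nM and so holds the only actual number so far. Compound 3 `OC[C@H]1O[C@@H](n2cnc3c(Cl)ncnc32)CS1` differs from it as follows: the two compounds have the same atoms and bonds and differ only in configuration as drawn: 1 of 2 stereo elements differ; a stereocentre at a saturated ring carbon is drawn S in compound 2 and R in compound 3 with a stereocentre at a saturated ring carbon drawn S in compound 2 and R in compound 3. Going by the values given here, no measured step shows what such a change does in this assay and none beyond the scatter is assumed. The expected change is a 1.1-fold lower number from compound 2 to compound 3 (0.03 log units; within the scatter) in this estimate. Compound 3 is expected at 80000 nM within an estimated range of 25000 nM to 200000 nM for now.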

Compound 3, half-maximal inhibitory concentration: 46500 nM
The estimate for compound 3 lay 1.7-fold (0.24 log units) above the measured number; low and high end bracket the measured number.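

In this assay the switch of this saturated ring carbon from S to R now has a measured step (a 1.9-fold lower number from compound 2 to compound 3 (0.27 log units; within the scatter)), so configuration at this stereocentre shows no effect that can be told from the scatter. Compound 1 stands at > 100000 nM as a limit of the assay. Hydrogen in place of amino on an aromatic carbon goes with a step read against that limit (an at least 2.1-fold lower number from compound 1 to compound 3 (0.33 log units; beyond the scatter)).

The compounds shown leave open whether the second stereocentre matters. They also leave open whether an amine or a carboxylic acid on the shared core would move the number beyond the scatter.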